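Chalcone-pyrazole series: removing the aniline amino group

This account rests on a few compounds, and the source may have more. Where it says the series, first, only, none or still open, it means among the compounds named here.

Measured compounds so far:
- compound 1, `COc1cc(-c2cc(/C=C/C(=O)c3ccc(N)cc3)[nH]n2)cc(OC)c1OC`: 1600 nM
- compound 2, `COc1cc2c(cc1OC)C(=O)/C(=C/c1cc(-c3cc(OC)c(OC)c(OC)c3)n[nH]1)C2`: 2000 nM
- compound 3, `COc1ccc(-c2cc(/C=C/C(=O)c3ccc(N)cc3)[nH]n2)cc1OC`: 1900 nM

All three values come from a functional assay on MCF7 cells (Homo sapiens) for inhibition, read by MTT assay, with a stated time of 48 h; a higher number here means a weaker inhibitor, a lower number a stronger inhibitor. Compound 1 gives the lowest number of the three, but its separation from compound 3 and from compound 2 lies within the scatter, so no ordering among them can be claimed. Among the compounds with values here, the one step that can be followed between measured compounds, a 1.2-fold higher number from compound 1 to compound 3 (0.07 log units; within the scatter), shows that trimming a methoxy from the trimethoxyphenyl side leaves the number essentially unchanged.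

Compound 4, `COc1cc(-c2cc(/C=C/C(=O)c3ccccc3)[nH]n2)cc(OC)c1OC`, is compound 1 with the change (hydrogen in place of amino on an aromatic carbon). Within the data shown here, no measured pair isolates this change; the only comparable information is the methoxy removal from compound 1 to compound 3, which was flat. With no evidence that a peripheral deletion shifts the number, the expectation for compound 4 is a step of no more than the scatter, a 1.4-fold higher number from compound 1 to compound 4 (0.14 log units; within the scatter), leaning to a slightly higher number. The estimated value for compound 4 in this assay is 2200 nM, within 800 nM to 6000 nM.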

Compound 4, half-maximal inhibitory concentration: 2100 nM
For compound 4 the middle estimate is 1.0-fold (0.02 log units) above the measured one, and the stated range covers the measured number.
By their numbers in this assay, from the lowest: compounds 1, 3, 2 and 4 (each within the scatter of the next).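

In this assay, the change from 4-aminophenyl to phenyl gives the series its first single-change test at this position, on an aromatic carbon para to a large group (a 1.3-fold higher number from compound 1 to compound 4 (0.12 log units; within the scatter)). The amino group, with its hydrogen-bond donor and acceptor, can therefore leave this position without a step beyond the scatter. Together with the methoxy change (a 1.2-fold higher number from compound 1 to compound 3 (0.07 log units; within the scatter)), this gives two single-place changes on compound 1, neither beyond the scatter. No data on why the number holds are available.

On these data alone, it remains open whether a carboxylic acid or an acetamide at this same position would shift the number beyond the scatter. Also open, as far as these compounds go, is whether replacing the amino group with hydrogen on compound 3 would give a similarly small step.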